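The source may report more compounds than this note shows. Statements on the series, on what has been measured and on what is new or still open speak of the compounds shown alone.

Working notes on the benzylcarbamate series in an assay for inhibition of zeta-carotene desaturase, chloroplastic/chromoplastic (Capsicum annuum), using a Dixon plot, with a stated time of 8 h; on this read-out higher numbers stand for weaker inhibition and lower numbers for stronger inhibition. Compound 1 `CCC(COc1cccc(C(F)(F)F)c1)OC(=O)NCc1ccccc1` sits at the assay limit, giving > 100000 nM. Compound 2 `CCC(COc1ccccc1Cl)OC(=O)NCc1ccccc1` likewise returns only a limit, > 100000 nM. Compound 3 `CCC(COc1ccc(Cl)cc1)OC(=O)NCc1ccccc1` also returns only a limit, > 100000 nM. The step that the two limits leave unreadable from compound 2 to compound 3 therefore cannot be read, since both of its ends sit at the limit of > 100000 nM in this assay, at which 3 of the 3 values shown sit. The next variant is compound 4 `CCC(COc1cccc(OC)c1)OC(=O)NCc1ccccc1`, which differs from compound 2 as follows: 3-methoxyphenyl in place of 2-chlorophenyl on an oxygen on a saturated carbon. For the measured compounds named here, no measured step bears on this change with a readable size; every value in the set is a limit. Compound 4 is therefore expected to remain at the limit as well, with the step that the limit leaves unreadable from compound 2 to compound 4 expected to show no readable change. The estimate for compound 4 is 200000 nM, within the range 50000 nM to 1000000 nM, most probably reported only as a limit.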

Compound 4, half-maximal inhibitory concentration: > 100000 nM
Compound 4 ended at the assay's limit; the forecaster's own chance of this, stated with the estimate: 85%; the middle value is on the limit's open side.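

Compound 4 gives > 100000 nM, which is a limit, so its steps from compound 1, compound 2 and compound 3 cannot be read: the limit of > 100000 nM in this assay, at which 4 of the 4 values shown sit.

The compounds shown leave open which change to the shared core, if any, would give a readable value in this assay.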